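The source may hold more compounds than are shown below. What is called first, only, known or untested is meant among the compounds shown, and "the series" means these compounds.

Of the compounds shown here, three built on one shared core have been measured in an assay for inhibition of acid-sensing ion channel 3 (Homo sapiens), read by patch clamp, tested at 20 uM; on this read-out higher numbers stand for more inhibition at the one concentration tested (going by the name of the read-out) and lower numbers for less inhibition. Compound 1 `NC(N)=NC(=O)c1nc(Cl)c(NCc2cccc(F)c2)nc1N` gives 90% and compound 3 `NC(N)=NC(=O)c1nc(Cl)c(N2CCc3ccccc32)nc1N` gives 89%, while compound 2 `NC(N)=NC(=O)c1nc(Cl)c(NC2CC2)nc1N` gives 78%, the lowest of the three numbers, with both other values beyond the scatter above it. Compound 4 `NC(N)=NC(=O)c1nc(Cl)c(Nc2ccccc2)nc1N` has not yet been measured; it differs from compound 2 by phenyl in place of cyclopropyl on a nitrogen on an aromatic ring. Going by the values given here, no step between measured compounds that differ in a single place is available, so the direction can only be judged from the values themselves. Because compound 1 sits at 90% and compound 3 at 89%, a moderate upward step beyond the scatter is expected. Compound 4 is estimated at 85%, with a range from 70% to 95%, which means an expected step of a number 7 percentage points higher from compound 2 to compound 4 (within the scatter).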

Compound 4, a percentage reported as inhibition, at one concentration (the size of the read-out at that concentration, not a potency): 95%
For compound 4 the middle estimate is 10 percentage points below the measured one; low and high end bracket the measured number.
By their numbers in this assay, from the lowest: compound 2; then compounds 3, 1 and 4 (each within the scatter of the next).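

In this assay, going by these compounds alone, this is the first comparison at this position that changes one group alone: phenyl in place of cyclopropyl on the nitrogen gives a step of a number 17 percentage points higher from compound 2 to compound 4 (beyond the scatter). The position therefore responds to the group it carries, and a six-membered aromatic ring here gives more inhibition than a three-membered non-aromatic one. Nothing available explains this step.

From the compounds shown here alone, it remains open whether an amine or a carboxylic acid on the phenyl ring would keep this level of inhibition. Going by these compounds, a longer carbon chain in place of the ring is also open.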